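This account rests on a few compounds, and the source may have more. Where it says the series, first, only, none or still open, it means among the compounds named here.

Compound 1 `CCCCOc1nc(OCC(C)(C)O)c(-c2ccc(S(C)(=O)=O)cc2)cc1CO` stands lowest of the three measured compounds: in an ADME assay on Colon (Homo sapiens) for protein binding (a lower number here means a smaller unbound share, a higher number a larger unbound share of the compound), compound 1 gives 0.025. Compound 2 `CCCCOc1nc(OCC2(O)CCC2)c(-c2ccc(S(C)(=O)=O)cc2)cc1CO` gives 0.055, and compound 3 `CC(C)(O)COc1nc(OCCC(F)(F)F)c(CO)cc1-c1ccc(S(C)(=O)=O)cc1` gives 0.224. Compound 4 `CC(C)(O)COc1nc(OCCCC(F)(F)F)c(CO)cc1-c1ccc(S(C)(=O)=O)cc1` is not yet measured. Its change from compound 1 is trifluoromethyl in place of methyl on a saturated chain carbon, three bonds along the chain from an oxygen on an aromatic ring, so butyl becomes 4,4,4-trifluorobutyl. The closest measured precedent is a 9.0-fold higher number from compound 1 to compound 3 (0.95 log units; beyond the scatter), with trifluoromethyl in place of ethyl two bonds along the chain. The step of a 2.2-fold higher number from compound 1 to compound 2 (0.34 log units; beyond the scatter), with 1-hydroxycyclobutyl in place of 1-hydroxy-1-methylethyl, concerns a different group and bears on this change only weakly. Among the compounds with values here, no measured pair shows how the size of the step varies with the chain, so the single precedent is taken with caution and a smaller rise than it showed is expected. The expected change in this assay is upward, estimated as a 4.0-fold higher number from compound 1 to compound 4 (0.60 log units; beyond the scatter). Compound 4 is estimated at 0.1, with an expected range of 0.045 to 0.22.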

Compound 4, unbound fraction: 0.204
For compound 4 the middle estimate is 2.0-fold (0.31 log units) below the measured one; the measured number falls inside the stated range.
By their numbers in this assay, from the lowest: compound 1; then compound 2; then compounds 4 and 3 (each within the scatter of the next).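

In this assay, trifluoromethyl in place of methyl at the end of the chain, turning butyl into 4,4,4-trifluorobutyl, gives an 8.2-fold higher number from compound 1 to compound 4 (0.91 log units; beyond the scatter), so the rise is not confined to the 3,3,3-trifluoropropyl chain of compound 3. The comparison of the two fluorinated chains gives a 1.1-fold lower number from compound 3 to compound 4 (0.04 log units; within the scatter), so this assay does not separate 3,3,3-trifluoropropyl from 4,4,4-trifluorobutyl, and placing the trifluoromethyl two or three bonds along the chain makes no readable difference here. Nothing among the data offers an explanation for the size of either step.

Still open, on these data alone, is whether a longer chain such as 5,5,5-trifluoropentyl, or a chain ending in a nitrile or a carboxylic acid, would stay at this level. Also open, as far as these compounds go, is whether the same change carries over when 1-hydroxycyclobutyl stands in place of 1-hydroxy-1-methylethyl.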